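The source may hold more compounds than are shown below. What is called first, only, known or untested is meant among the compounds shown, and "the series" means these compounds.

Working notes on the series. Compound 1 `O=C(Nc1cccc(-n2cc(-c3ccncc3)c(-c3cc(O)cc(Cl)c3)n2)c1)Nc1ccc(Cl)c(C(F)(F)F)c1` is the reference of the first pair; in a functional assay on CAKI-1 cells (Homo sapiens) for inhibition, read by sulforhodamine B assay, with a stated time of 48 h, tested at 10 uM (a lower number here means a stronger effect, a higher number a weaker effect of the compound at the concentration tested), compound 1 gives 29.1%. Compound 2 `COc1cc(Cl)cc(-c2nn(-c3cccc(NC(=O)Nc4ccc(Cl)c(C(F)(F)F)c4)c3)cc2-c2ccncc2)c1` differs from compound 1 only by methyl in place of hydrogen on an oxygen on an aromatic ring, and in this assay compound 2 gives 9.38%, so that the hydroxy to methoxy change made a step of a number 19.7 percentage points lower from compound 1 to compound 2 (beyond the scatter). Compound 3 `O=C(Nc1cccc(-n2cc(-c3ccncc3)c(-c3cc(O)cc(Cl)c3)n2)c1)c1cc(C(F)(F)F)cc(C(F)(F)F)c1` differs from compound 1 in a larger part of the molecule; the difference between the two cores is not broken down here. In this assay compound 3 gives 58.5%, the highest of the three numbers, beyond the scatter from both compound 1 and compound 2. Compound 4 `COc1cc(Cl)cc(-c2nn(-c3cccc(NC(=O)c4cc(C(F)(F)F)cc(C(F)(F)F)c4)c3)cc2-c2ccncc2)c1` has not yet been measured; it differs from compound 3 by methyl in place of hydrogen on an oxygen on an aromatic ring, the same change as between compound 1 and compound 2, at the same place. For the measured compounds named here, the only guide is that single step, made on a different core, so the expectation is tentative: the step from compound 3 to compound 4 is expected to be about a number 18.5 percentage points lower from compound 3 to compound 4 (beyond the scatter), because the same change gave a number 19.7 percentage points lower from compound 1 to compound 2 (beyond the scatter). Compound 4 is estimated at 40%, with a likely range from 24% to 58%.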

Compound 4, a percentage reported as activity, at one concentration (the size of the read-out at that concentration, not a potency): 68.6%
Estimate against measurement, compound 4: 28.6 percentage points below; measured number outside the range, above it.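

In this assay, the hydroxy to methoxy change on the core of compound 3 gives a step of a number 10.1 percentage points higher from compound 3 to compound 4 (beyond the scatter), so its direction is opposite to that of the step on the core of compound 1, and the two steps do not agree: the same change on two cores in this assay, a number 19.7 percentage points lower (beyond the scatter) from compound 1 to compound 2 and a number 10.1 percentage points higher (beyond the scatter) from compound 3 to compound 4, 29.8 percentage points apart, beyond the scatter of two such steps

In these two pairs, then, the effect of this change on the 3-chloro-5-hydroxyphenyl group does not carry from one core to the other, and a step read on one core is no guide to its size or direction on the other. The pairs do not show which part of the difference between the cores goes with the reversal, nor why it occurs, and two pairs at a single concentration set no rule for any further core.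

Open, from the compounds shown here alone, is how an ethoxy group or an amine in place of the hydroxy group would behave on each core. Also open, going by these compounds, is whether a third core would follow compound 1 and compound 2 or compound 3 and compound 4.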